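Amide substituent variation on the shared core: antiproliferative readout

A few compounds are considered here, and "the series" means these few. Any claim that something is new, unique, unknown or untested is made for them only; others in the source may bear on it.

Among the compounds with values here, compound 2 `CCOC(=O)C(CC(=O)OC)NC(=O)c1ccc(C(CC)(CC)c2ccc(OCCC(O)(CC)CC)c(C)c2)n1CC` is the only compound of the pair with a number in an ADME assay on L02 cells (Homo sapiens) for antiproliferative activity, read by MTT assay, with a stated time of 48 h (a lower number here means a stronger inhibitor, a higher number a weaker inhibitor), where compound 2 gives 4280 nM. Compound 1 `CCn1c(C(=O)Nc2ccc(OC(F)(F)F)cc2)ccc1C(CC)(CC)c1ccc(OCCC(O)(CC)CC)c(C)c1` gives only a limit in this assay, > 50000 nM. Within the data shown here, the one measured step, an at least 11-fold lower number from compound 1 to compound 2 (1.06 log units; beyond the scatter), starts from the limit (the limit of > 50000 nM in this assay, at which 1 of the 2 values shown sits). Compound 3 `CCC(C)C(CO)NC(=O)c1ccc(C(CC)(CC)c2ccc(OCCC(O)(CC)CC)c(C)c2)n1CC` differs from compound 2 in a group of 7 heavy atoms (6 carbon, 1 oxygen; no ring) in place of a group of 11 heavy atoms (7 carbon, 4 oxygen; no ring), on an amide-type nitrogen. Among the measured compounds shown here, no measured step covers this change, so the expected step of a 1.9-fold higher number from compound 2 to compound 3 (0.27 log units; within the scatter) is modest and uncertain in direction, leaning toward a higher number. Compound 3 is therefore estimated at 8000 nM, within 2500 nM to 30000 nM.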

Compound 3, half-maximal inhibitory concentration: > 50000 nM
Compound 3 gave a limit, no number (the forecaster's own chance of this, stated with the estimate: 25%); at least 6.2-fold (0.79 log units) between middle value and limit.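

At the amide-type nitrogen, a ring-free group is not enough on its own: 1-(hydroxymethyl)-2-methylbutyl in place of the group of compound 2 gives an at least 11-fold higher number from compound 2 to compound 3 (1.06 log units; beyond the scatter) in this assay, so the measured number belongs to that particular group and not simply to the absence of 4-(trifluoromethoxy)phenyl. The result for compound 3 is a limit, not a number, and compound 1 sits at the same limit: the limit of > 50000 nM in this assay, at which 2 of the 3 values shown sit. The step between these two compounds cannot be read.

Open, as far as these compounds go, is which part of the group of compound 2 carries the effect. Also open, from the compounds shown here alone, is how an amine or a carboxylic acid on this nitrogen would read.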